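Swapping the sulfonyl aryl group: a clearance estimate

The compounds below may be only part of what the source reports. "The series", "measured", "known", "first", "only" and "open" are said of these compounds alone.

Compound 3 `COc1ccc(-c2c(S(=O)(=O)c3ccc(F)c(F)c3)cnc3c(F)cccc23)cc1` gives the highest number of the three measured compounds in an ADME assay on microsomes from liver (Homo sapiens) for metabolic stability, tested at 2.5 uM (a lower number here means slower removal, a higher number faster removal of the compound), at 2.12 mL/min. Among the compounds with values here, compound 1 `O=S(=O)(c1cc(Cl)cc(Cl)c1)c1cnc2c(F)cccc2c1-c1ccccc1F` gives 0.44 mL/min and compound 2 `O=S(=O)(c1cc(Cl)cc(Cl)c1)c1cnc2c(F)cccc2c1-c1cccc(F)c1` gives 1.08 mL/min; the single measured step, a 2.5-fold higher number from compound 1 to compound 2 (0.39 log units; beyond the scatter), concerns the fluorophenyl on the aromatic carbon and does not touch the sulfonyl aryl group. Compound 4 `COc1ccc(-c2c(S(=O)(=O)c3cc(Cl)cc(Cl)c3)cnc3c(F)cccc23)cc1` differs from compound 3 by 3,5-dichlorophenyl in place of 3,4-difluorophenyl on a sulfonyl sulfur. Within the data shown here, no measured step bears directly on this change; compounds 1 and 2 carry the same 3,5-dichlorophenyl and show lower numbers than compound 3, but they differ from it in a second place too. Compound 4 is therefore expected to give a somewhat lower number, a 1.8-fold lower number from compound 3 to compound 4 (0.25 log units; within the scatter), in this assay. The estimate for compound 4 is 1.2 mL/min, between 0.5 mL/min and 2.8 mL/min.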

Compound 4, intrinsic clearance in a liver preparation (reported as CLH), per the amount of preparation that the assay uses: 2.11 mL/min
Beside the measured number, compound 4's estimate is 1.8-fold (0.25 log units) below it; measured number inside the range.
By their numbers in this assay, from the lowest: compound 1; then compounds 2, 4 and 3 (each within the scatter of the next).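

On the sulfonyl sulfur, 3,5-dichlorophenyl in place of 3,4-difluorophenyl gives no difference beyond the scatter in this assay (a 1.0-fold lower number from compound 3 to compound 4 (0.00 log units; within the scatter)). With 3,5-dichlorophenyl held fixed, 4-methoxyphenyl in place of 2-fluorophenyl on the aromatic carbon gives a step beyond the scatter (a 4.8-fold higher number from compound 1 to compound 4 (0.68 log units; beyond the scatter)), whereas 4-methoxyphenyl in place of 3-fluorophenyl stays within it (a 2.0-fold higher number from compound 2 to compound 4 (0.29 log units; within the scatter)). Nothing available explains these results. Within the data shown here, only two dihalophenyl groups appear on the sulfonyl sulfur here. As far as these compounds go, whether an amine or a carboxylic acid on that phenyl ring would shift the number remains open.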